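A Ring Swap on the Sulfur of Compound 3

This account rests on a few compounds, and the source may have more. Where it says the series, first, only, none or still open, it means among the compounds named here.

Measured compounds and their values in a functional assay on Huh-7 cells (Homo sapiens) for inhibition, read by MTT assay, with a stated time of 72 h; on this read-out higher numbers stand for weaker inhibition and lower numbers for stronger inhibition:
Compound 1, `C/C(=N\NC(=O)CSc1nc2ccccc2s1)c1ccc(C)c([N+](=O)[O-])c1`: 10.1 ug/mL
Compound 2, `C/C(=N\NC(=O)CSc1nc2ccccc2s1)c1ccc([N+](=O)[O-])cc1`: 39.7 ug/mL
Compound 3, `O=C(N/N=C/c1c[nH]c2ccccc12)c1ccc(CSc2nc3ccccc3s2)cc1`: 7.74 ug/mL

Compound 3 gives the lowest of the three numbers. Compound 1 sits within the usual scatter of it, so no order between these two can be claimed; compound 2 stands clearly higher, beyond the scatter. Compound 4, `Cc1cc(C)nc(SCc2ccc(C(=O)N/N=C/c3c[nH]c4ccccc34)cc2)n1`, differs from compound 3 in one place: 4,6-dimethylpyrimidin-2-yl in place of 1,3-benzothiazol-2-yl on a sulfur. Going by the values given here, no measured pair shows what such a swap does, so there is no step to size it from. The expectation rests on compound 3 alone, and the step of a 1.4-fold higher number from compound 3 to compound 4 (0.15 log units; within the scatter) is expected to be small, a slight weakening or none beyond the scatter. Compound 4 is therefore estimated at 11 ug/mL, within a range from 4 ug/mL to 30 ug/mL.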

Compound 4, half-maximal inhibitory concentration: 23.2 ug/mL
The estimate for compound 4 lay 2.1-fold (0.32 log units) below the measured number; the range from low to high includes it.
By their numbers in this assay, from the lowest: compounds 3 and 1 (each within the scatter of the next); then compounds 4 and 2 (each within the scatter of the next).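

The group on the sulfur matters: in this assay, 4,6-dimethylpyrimidin-2-yl in place of 1,3-benzothiazol-2-yl gives a 3.0-fold higher number from compound 3 to compound 4 (0.48 log units; beyond the scatter) and so weakens inhibition beyond the usual scatter. This single ring therefore does not stand in freely for the two-ring group at this position. Nothing available explains the size of this step. Still open, on these data alone, is how a plain pyridin-2-yl ring or a butyl chain on the sulfur would compare. Also open, as far as these compounds go, is whether the same swap would shift the number similarly in the core of compound 1.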